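Nitro for Fluoro on the Fused Ring of Compound 3

The source may report more compounds than this note shows. Statements on the series, on what has been measured and on what is new or still open speak of the compounds shown alone.

Compound 1 `O=C1Nc2ccccc2/C1=N/NC(=S)N1CCN(c2ccccc2)CC1`: 11100 nM
Compound 2 `Cc1ccc2c(c1)/C(=N/NC(=S)N1CCN(c3ccccc3)CC1)C(=O)N2`: 9480 nM
Compound 3 `O=C1Nc2ccc(F)cc2/C1=N/NC(=S)N1CCN(c2ccccc2)CC1`: 12400 nM

Three compounds share one core and differ only in a single substituent on the six-membered aromatic ring of carbon only. In a functional assay on HCT-116 cells (Homo sapiens) for inhibition, read by MTT assay, with a stated time of 72 h (on this read-out lower numbers stand for stronger inhibition and higher numbers for weaker inhibition), compound 1 gives 11100 nM, compound 2 gives 9480 nM and compound 3 gives 12400 nM. Compound 3 holds the highest of the three numbers, but a 1.1-fold higher number from compound 1 to compound 3 (0.05 log units; within the scatter) and a 1.3-fold higher number from compound 2 to compound 3 (0.12 log units; within the scatter) both lie within the scatter, as does a 1.2-fold lower number from compound 1 to compound 2 (0.07 log units; within the scatter).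

Compound 4 `O=C1Nc2ccc([N+](=O)[O-])cc2/C1=N/NC(=S)N1CCN(c2ccccc2)CC1` has not yet been measured. It differs from compound 3 by nitro in place of fluoro on an aromatic carbon. Going by the values given here, no measured step involves a nitro group, so nothing bears directly on this change; the three steps that exchange hydrogen, methyl and fluoro at this ring all stay within the scatter. The expectation for this assay is therefore a step of a 1.1-fold lower number from compound 3 to compound 4 (0.05 log units; within the scatter), nothing beyond the scatter. Compound 4 is expected to give 11000 nM, with a range from 4000 nM to 30000 nM.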

Compound 4, half-maximal inhibitory concentration: 15100 nM
For compound 4 the middle estimate is 1.4-fold (0.14 log units) below the measured one; low and high end bracket the measured number.
By their numbers in this assay, from the lowest: compounds 2, 1, 3 and 4 (each within the scatter of the next).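

Nitro in place of fluoro gives a 1.2-fold higher number from compound 3 to compound 4 (0.09 log units; within the scatter), nitro in place of methyl gives a 1.6-fold higher number from compound 2 to compound 4 (0.20 log units; within the scatter), and nitro in place of hydrogen gives a 1.4-fold higher number from compound 1 to compound 4 (0.13 log units; within the scatter). Nitro therefore joins hydrogen, methyl and fluoro as a fourth group on this aromatic carbon, and in this assay all four remain within the scatter of one another, so no group shown here separates from the rest. Nothing available explains why this position shows so little response to the change.

Going by these compounds, whether an amine, a carboxylic acid or a longer chain on this aromatic carbon would move the number beyond the scatter remains open. The compounds shown also leave open whether a change elsewhere on the shared core would do so.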